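The source may report more compounds than this note shows. Statements on the series, on what has been measured and on what is new or still open speak of the compounds shown alone.

Of the compounds shown here, two built on the same core have so far been measured in a physicochemical assay for lipophilicity; on this read-out lower numbers stand for lower lipophilicity and higher numbers for higher lipophilicity. Compound 1 `CCOc1ccccc1-c1nc(N)nc(N)n1` gives 1.03. Compound 2 `COc1ccccc1-c1nc(N)nc(N)n1` gives 0.58. Within the data shown here, the one step between them is a number 0.45 log units lower from compound 1 to compound 2 (beyond the scatter). Among the measured compounds shown here, compound 2 therefore stands at the lower of the two numbers, with compound 1 as its only neighbour, a clear distance above it.

Compound 3 `Cc1ccccc1-c1nc(N)nc(N)n1` has not yet been measured in this assay. It differs from compound 2 by methyl in place of methoxy on an aromatic carbon. For the measured compounds named here, the single measured step concerns a different kind of change, the loss of one carbon from a chain while the oxygen stays in place, so it is only a loose guide here, where the oxygen itself leaves and one carbon remains attached to the ring. The expected step is a number 0.52 log units higher from compound 2 to compound 3 (beyond the scatter), a rise beyond the scatter. Compound 3 is estimated at 1.1, with a likely range from 0.7 to 1.5.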

Compound 3, partition coefficient: 1.26
For compound 3 the middle estimate is 0.16 log units below the measured one; low and high end bracket the measured number.
By their numbers in this assay, from the lowest: compound 2; then compounds 1 and 3 (each within the scatter of the next).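

In this assay, methyl in place of methoxy on this aromatic carbon gives a number 0.68 log units higher from compound 2 to compound 3 (beyond the scatter) and so shows that a change removing the oxygen, not only one shortening the chain on it, can move the number beyond the scatter. Methyl in place of ethoxy gives a number 0.23 log units higher from compound 1 to compound 3 (within the scatter) and leaves those two compounds indistinguishable here, so among these three groups only methoxy stands apart, with compound 2 lowest. No measurement available here explains why these groups fall as they do.

As far as these compounds go, it remains open where an ethyl chain or an amine on this carbon would fall relative to these three groups. A longer ether such as propoxy could also show whether the difference seen between methoxy and ethoxy continues as the chain grows.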